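Triple bond in place of a double bond on the core

The compounds below may be only part of what the source reports. "The series", "measured", "known", "first", "only" and "open" are said of these compounds alone.

The series rests on a small set of measurements in a functional assay on HCT-116 cells (Homo sapiens) for cytotoxicity, with a stated time of 3 days; a higher number here means a weaker inhibitor, a lower number a stronger inhibitor. Compound 1, `C=Cc1nc2ccccc2s1`, sits at a limit of the assay rather than a number: in this assay compound 1 gives > 40000 nM. Compound 2, `C=Cc1sc(-c2ccc(F)cc2)nc1C(=O)OCC`, also returns only a limit, giving > 40000 nM in this assay. Within the data shown here, compound 3, `C#Cc1nc2ccccc2o1`, is the one member with a measured number, giving 11600 nM in this assay. So compound 1 stands at the weak end of what has been seen, at the limit of > 40000 nM in this assay, at which 2 of the 3 values shown sit, and no step between measured compounds can be drawn from these three structures.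

The step to compound 4, `CC#Cc1nc2ccccc2s1`, changes one place on the core of compound 1: prop-1-yn-1-yl in place of vinyl on an aromatic carbon. Among the measured compounds shown here, no measured pair isolates this change, so its size can only be estimated. Compound 3 shows that a compound with a triple bond on a fused core of this kind can give a number within range, whereas compound 1 with its vinyl does not, which suggests a step toward stronger inhibition that may or may not exceed the scatter. The expected step from compound 1 to compound 4 is an at least 2.0-fold lower number from compound 1 to compound 4 (0.30 log units; that floor lies within the scatter). Compound 4 is therefore estimated at 20000 nM in this assay, with a range from 6000 nM to 60000 nM, and a real chance that only a limit is reported again.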

Compound 4, half-maximal inhibitory concentration: > 40000 nM
Compound 4 gave a limit, no number; the forecaster's own chance of this, stated with the estimate: 40%; at least 2.0-fold (0.30 log units) between middle value and limit.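

In this assay compound 4 returns only a limit, > 40000 nM. Among these compounds, compound 1 also stands at a limit, so no step between compound 1 and compound 4 can be read: the limit of > 40000 nM in this assay, at which 3 of the 4 values shown sit. The compounds shown leave open whether any group in place of vinyl on the core of compound 1 gives a measured number in this assay.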